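The compounds below may be only part of what the source reports. "The series", "measured", "known", "first", "only" and "open" are said of these compounds alone.

Three compounds built on one shared core, each carrying a different group on an aromatic carbon, have been tested in an ADME assay on J774 cells (Mus musculus) for cytotoxicity, read by MTT assay, with a stated time of 48 h, tested at 50 ug/mL; a lower number here means a stronger effect, a higher number a weaker effect of the compound at the concentration tested. Compound 1, `O=C(N/N=C/c1ccc(Cl)cc1)c1cnccn1`, gives 83% in this assay. Compound 2, `O=C(N/N=C/c1ccc(F)cc1)c1cnccn1`, gives 78%. Compound 3, `O=C(N/N=C/c1ccc(Br)cc1)c1cnccn1`, gives 100%, the highest of the three numbers; the two steps that end at it are a number 17 percentage points higher from compound 1 to compound 3 (beyond the scatter) and a number 22 percentage points higher from compound 2 to compound 3 (beyond the scatter), while the pair of compounds 1 and 2 differs only by a number 5 percentage points lower from compound 1 to compound 2 (within the scatter).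

Compound 4, `COc1ccc(/C=N/NC(=O)c2cnccn2)cc1`, has not yet been measured in this assay. It differs from compound 3 in one place: methoxy in place of bromo on an aromatic carbon. None of the three measured steps involves a methoxy group; the two steps that end at compound 3 both swap one halogen for another, and they moved the number by modest amounts. For the measured compounds named here, no measured step tells how this core behaves once a methoxy group replaces a halogen, so the expectation rests only on the spread already seen among compounds 1, 2 and 3. The step from compound 3 to compound 4 is expected to be a number 15 percentage points lower from compound 3 to compound 4 (beyond the scatter). Compound 4 is estimated to give 85% in this assay, within a range from 65% to 100%.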

Compound 4, a percentage reported as activity, at one concentration (the size of the read-out at that concentration, not a potency): 74%
Beside the measured number, compound 4's estimate is 11 percentage points above it; low and high end bracket the measured number.
By their numbers in this assay, from the lowest: compounds 4, 2 and 1 (each within the scatter of the next); then compound 3.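

In this assay, for the compounds shown here, the earlier compounds compared only halogens, and this result shows that the position on an aromatic carbon para to a large group can also hold a non-halogen group without setting the compound apart from the fluoro and chloro compounds: methoxy gives a number 4 percentage points lower from compound 2 to compound 4 (within the scatter) and a number 9 percentage points lower from compound 1 to compound 4 (within the scatter). Bromo is now the one group that stands alone, since the change from it to methoxy, which swaps one heavy atom with no hydrogen-bond acceptor for two heavy atoms with one, gives a number 26 percentage points lower from compound 3 to compound 4 (beyond the scatter), and compound 3 lies beyond the scatter from all three other compounds. Nothing available explains why bromo alone differs here.

From the compounds shown here alone, whether an amine, a carboxylic acid or a longer chain such as ethoxy at this position would fall with compound 1, compound 2 and compound 4 or with compound 3 remains open. Each number is also a read-out at a single concentration, so how these compounds compare across a range of concentrations is open too.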